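From benzyl to aryl urea on the ring nitrogen

A few compounds are considered here, and "the series" means these few. Any claim that something is new, unique, unknown or untested is made for them only; others in the source may bear on it.

In a functional assay on cells (T-cell, Homo sapiens) for inhibition (on this read-out higher numbers stand for weaker inhibition and lower numbers for stronger inhibition), compound 1 `COc1ccc(-c2cnc3nc(N)nc(N4CCN(C(=O)COc5ccccc5)CC4)c3n2)cc1OC` gives 4 nM. Compound 2 `COc1ccc(-c2cnc3nc(N)nc(N4CCN(Cc5c(Cl)cccc5Cl)CC4)c3n2)cc1OC` gives 7600 nM, the higher of the two numbers shown, after the step of a 1900-fold higher number from compound 1 to compound 2 (3.28 log units; beyond the scatter). Compound 3 `CC(C)Oc1nc(N)nc2ncc(-c3ccc(C(F)(F)F)cc3)nc12` is reported in this assay only as a limit, > 10000 nM.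

Compound 4 `COc1ccc(-c2cnc3nc(N)nc(N4CCN(C(=O)Nc5ccc(F)cc5)CC4)c3n2)cc1OC` differs from compound 2 by (4-fluorophenyl)carbamoyl in place of 2,6-dichlorobenzyl on an amine nitrogen in a ring. Among the measured compounds shown here, only the step from compound 1 to compound 2 bears on this change, and it was large; compound 4 again carries a carbonyl on the ring nitrogen, as compound 1 does with its 4 nM. A large decrease is therefore expected, a 510-fold lower number from compound 2 to compound 4 (2.70 log units; beyond the scatter). Compound 4 is estimated at 15 nM in this assay, within a range from 3 nM to 150 nM.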

Compound 4, half-maximal inhibitory concentration: 7 nM
Estimate against measurement, compound 4: 2.1-fold (0.33 log units) above; low and high end bracket the measured number.
By their numbers in this assay, from the lowest: compounds 1 and 4 (each within the scatter of the next); then compound 2. At a limit, above all of these: compound 3.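

In this assay, the step of a 1100-fold lower number from compound 2 to compound 4 (3.04 log units; beyond the scatter) shows that a second carbonyl-bearing group on the ring nitrogen, here a urea, also gives a low number, so the result of compound 1 does not depend on the phenoxyacetyl group alone. The step of a 1.8-fold higher number from compound 1 to compound 4 (0.24 log units; within the scatter) shows that the amide and the urea cannot be told apart at this position. Nothing given here accounts for the change. As far as these compounds go, it remains open whether an unsubstituted benzyl would stay with compound 2, and whether a small acetyl or a methanesulfonyl group on that nitrogen would match compound 1 and compound 4.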